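The source may report more compounds than this note shows. Statements on the series, on what has been measured and on what is new or still open speak of the compounds shown alone.

Series values in a functional assay on MCF-10A cells (Homo sapiens) for antiproliferative activity, with a stated time of 48 h; on this read-out lower numbers stand for an effect already at smaller amounts and higher numbers for an effect only at larger amounts of compound

compound 1 `COc1ccc2nc(C)cc(NCc3cccc(F)c3)c2c1` gives 11300 nM
compound 2 `COc1ccc2nc(C)cc(NCc3ccccc3F)c2c1` gives 14000 nM

Among the compounds with values here, compound 1 has compound 2 as its only measured neighbour, and the two lie within the scatter of each other. Compound 3 `COc1ccc2nc(C)cc(NCc3cccc(C#N)c3)c2c1` has cyano in place of fluoro on an aromatic carbon. The nearest measured change, 2-fluorophenyl in place of 3-fluorophenyl, gave a 1.2-fold higher number from compound 1 to compound 2 (0.09 log units; within the scatter). Within the data shown here, no measured step replaces fluoro, so this is weak guidance and the range stays wide. The expected change in this assay is a 1.1-fold higher number from compound 1 to compound 3 (0.03 log units; within the scatter), with no step beyond the scatter anticipated. For compound 3 the estimate is 12000 nM, with an expected range from 5000 nM to 30000 nM.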

Compound 3, half-maximal effective concentration: 13400 nM
Compound 3: middle estimate off by 1.1-fold (0.05 log units), on the low side; the range from low to high includes it.
By their numbers in this assay, from the lowest: compounds 1, 3 and 2 (each within the scatter of the next).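

In this assay cyano in place of fluoro on an aromatic carbon gives a 1.2-fold higher number from compound 1 to compound 3 (0.07 log units; within the scatter) and so stays within the scatter. At this place, meta to a large group, the series thus accepts a group with one more heavy atom, a triple bond and a hydrogen-bond acceptor with no measurable shift in the read-out. No supporting measurement bears on this result.

On these data alone, whether an amine or a carboxylic acid at this place would move the number beyond the scatter remains open. So does whether any replacement here can reach lower numbers.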